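The source may report more compounds than this note shows. Statements on the series, on what has been measured and on what is new or still open speak of the compounds shown alone.

Compound 1 `O=C(/N=C(/NC(=O)c1cc(-c2ccccc2)nc2ccccc12)[Se]Cc1ccccc1)c1cc(-c2ccccc2)nc2ccccc12` gave 8460 nM in a functional assay on MCF7 cells (Homo sapiens) for cytotoxicity, read by MTT assay, with a stated time of 72 h; a higher number here means a weaker inhibitor of growth, a lower number a stronger inhibitor of growth. Compound 2 `O=C(/N=C(/NC(=O)c1cccs1)[Se]Cc1ccccc1)c1cccs1` gave 72500 nM in this assay. Compound 3 `CS/C(=N\C(=O)c1cccs1)NC(=O)c1cccs1` gave 44500 nM in this assay.

Compound 1 has the lowest of the three numbers, and its gaps to compound 3 and to compound 2 are both beyond the scatter. The difference between the core of compound 1 and the core of compound 2 is not broken down here. Compound 3 differs from compound 2 in one place (a group of 2 heavy atoms (1 carbon, 1 sulfur; no ring) in place of a group of 8 heavy atoms (7 carbon, 1 selenium; one six-membered aromatic ring of carbon only), on a carbon with a double bond to nitrogen), and that change gave a 1.6-fold lower number from compound 2 to compound 3 (0.21 log units; within the scatter).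

Compound 4 `CS/C(=N\C(=O)c1cc(-c2ccccc2)nc2ccccc12)NC(=O)c1cc(-c2ccccc2)nc2ccccc12` has not yet been measured. It differs from compound 1 in the same way (a group of 2 heavy atoms (1 carbon, 1 sulfur; no ring) in place of a group of 8 heavy atoms (7 carbon, 1 selenium; one six-membered aromatic ring of carbon only), on a carbon with a double bond to nitrogen). Since the same change gave a 1.6-fold lower number from compound 2 to compound 3 (0.21 log units; within the scatter), a step of similar size is expected from compound 1, namely a 1.4-fold lower number from compound 1 to compound 4 (0.15 log units; within the scatter); the wider spread allows for the core being a different one. Compound 4 is therefore estimated at 6000 nM, expected to lie between 2000 nM and 18000 nM.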

Compound 4, concentration for 50% growth inhibition: 43100 nM
For compound 4 the middle estimate is 7.2-fold (0.86 log units) below the measured one; the measured number lies above the stated range.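

In this assay, putting methylsulfanyl in place of the selenium-bearing group gave a 5.1-fold higher number from compound 1 to compound 4 (0.71 log units; beyond the scatter). The change therefore did not carry over unchanged from one core to the other in this assay: the same change on two cores in this assay, a 1.6-fold lower number (0.21 log units; within the scatter) from compound 2 to compound 3 and a 5.1-fold higher number (0.71 log units; beyond the scatter) from compound 1 to compound 4, 8.3-fold (0.92 log units) apart, beyond the scatter of two such steps

This shows that the size of the step depended on the core in these two pairs, but two pairs give no general rule and do not show which part of the core matters. The change also replaces selenium with sulfur and removes the ring in a single step, so the compounds shown do not separate these two differences. As far as these compounds go, a methyl group on selenium or a longer chain on sulfur would each bear on this, and how either would behave on the two cores remains open.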